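Title: A methoxy group takes the place of bromine

The source may report more compounds than this note shows. Statements on the series, on what has been measured and on what is new or still open speak of the compounds shown alone.

The study reads out cytotoxicity in a functional assay on MT4 cells (Homo sapiens) for cytotoxicity; on this read-out higher numbers stand for lower toxicity in this test and lower numbers for higher toxicity in this test. Three compounds have numbers there. Compound 1 `Cc1nc(S)n(Nc2cccc(Cl)c2)c1-c1ccccc1` gives 66700 nM. Compound 2 `CC1N=CN(Nc2ccccc2)C1C` gives 351000 nM. Compound 3 `Cc1nc(S)n(Nc2cccc(Cl)c2)c1-c1ccc(Br)cc1` gives 33200 nM, the lowest of the three numbers, though the gap to compound 1 lies within the scatter; the gap to compound 2 lies beyond it.

Among the compounds with values here, one measured step touches the position in question: a 2.0-fold lower number from compound 1 to compound 3 (0.30 log units; within the scatter). Compound 4 `COc1ccc(-c2c(C)nc(S)n2Nc2cccc(Cl)c2)cc1` changes the same carbon again, with methoxy in place of bromo on an aromatic carbon. Within the data shown here, no measured pair shows a methoxy group entering at an aromatic carbon, so the size of this step rests on the single bromo step, which itself stayed within the scatter.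

On that basis the move is expected to be small. Compound 4 is expected to sit close to compound 3, with the step of a 1.5-fold higher number from compound 3 to compound 4 (0.18 log units; within the scatter) reflecting a slight drift back toward the number of compound 1 rather than a marked change. The estimate for compound 4 in this assay is 50000 nM, with a range from 20000 nM to 130000 nM.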

Compound 4, half-maximal cytotoxic concentration: 38700 nM
Compound 4: the middle estimate sits 1.3-fold (0.11 log units) above what was measured; the measured number falls inside the stated range.
By their numbers in this assay, from the lowest: compounds 3, 4 and 1 (each within the scatter of the next); then compound 2.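

Within the data shown here, the exchange of bromo for methoxy gives a 1.2-fold higher number from compound 3 to compound 4 (0.07 log units; within the scatter) in this assay and the comparison of methoxy with hydrogen, which no earlier pair offered, gives a 1.7-fold lower number from compound 1 to compound 4 (0.24 log units; within the scatter) at the same aromatic carbon. Together with the earlier bromo step, this closes the set: hydrogen, bromo and methoxy at this place, para to a large group, cannot be told apart on this read-out, even though the change replaces one heavy atom with two and brings in one hydrogen-bond acceptor. No supporting measurement accompanies these numbers, so the result can be described here but not explained.

The compounds shown leave open whether any group at this carbon would give a step beyond the scatter, for instance an amine, a carboxylic acid or a longer chain such as butoxy. They also leave open whether hydrogen, bromo and methoxy would remain indistinguishable if the chloro group on the other aromatic ring gave way to a different group, such as a nitrile.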